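Working notes: compound 1 to compound 3

The source may report more compounds than this note shows. Statements on the series, on what has been measured and on what is new or still open speak of the compounds shown alone.

- compound 1 `COc1cc(NC(C)CCCNC(=O)c2c(C)[n+]([O-])c3ccccc3[n+]2[O-])c2ncccc2c1`: 39500 nM
- compound 2 `COc1cc(NC(C)CCCNC(=O)c2c(C)[n+]([O-])c3ccc(Cl)cc3[n+]2[O-])c2ncccc2c1`: 155000 nM

In an ADME assay on HepG2 cells (Homo sapiens) for cytotoxicity, read by MTT assay, with a stated time of 48 h (a higher number here means that more compound is tolerated, a lower number that less compound is tolerated), compound 1 stands lowest of the two measured compounds, so less of it is tolerated than of compound 2. Compound 3 `COc1cc(NC(C)CCCNC(=O)c2c(C)[n+]([O-])c3ccc(OC)cc3[n+]2[O-])c2ncccc2c1` has not been measured. It differs from compound 1 by methoxy in place of hydrogen on an aromatic carbon. Going by the values given here, only one measured step bears on this, chloro in place of hydrogen on an aromatic carbon, which is modest in size: a 3.9-fold higher number from compound 1 to compound 2 (0.59 log units; beyond the scatter). A single step with a different entering group is thin support, so a smaller step in the same direction, one that may not clear the scatter, is expected in this assay. The expected step is a 1.8-fold higher number from compound 1 to compound 3 (0.25 log units; within the scatter). Compound 3 is estimated at 70000 nM, with an expected range of 30000 nM to 160000 nM.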

Compound 3, half-maximal cytotoxic concentration: > 203000 nM
Compound 3: a limit, no number (the forecaster's own chance of this, stated with the estimate: 5%); middle value at least 2.9-fold (0.46 log units) from the limit.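

In this assay compound 3 gives no number, only a limit of the assay: the limit of > 203000 nM in this assay, at which 1 of the 3 values shown sits. Methoxy in place of hydrogen gives an at least 5.1-fold higher number from compound 1 to compound 3 (0.71 log units; beyond the scatter), so two different entering groups on this aromatic carbon, chloro and methoxy, now go the same way. Methoxy in place of chloro gives an at least 1.3-fold higher number from compound 2 to compound 3 (0.11 log units; that floor lies within the scatter), so this floor sets no order between the two substituted compounds.

How far the methoxy step runs past the limit remains unknown, and only chloro and methoxy are shown on this aromatic carbon. Going by these compounds, whether an amine, a carboxylic acid or a longer chain such as ethoxy at the same place would also go with a higher number remains open.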